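The source may hold more compounds than are shown below. What is called first, only, known or untested is meant among the compounds shown, and "the series" means these compounds.

Measured compounds in a functional assay on CHO cells for antagonist activity at growth hormone secretagogue receptor type 1 (Homo sapiens); on this read-out lower numbers stand for stronger inhibition and higher numbers for weaker inhibition:
compound 1 `COc1ccc(Cn2c(CCc3ccccc3)nnc2[C@H](NC(=O)C(C)(C)N)c2c[nH]c3ccccc23)cc1` — 5 nM
compound 2 `COc1ccc(Cn2c(CCc3ccccc3)nnc2[C@H](NC(=O)CCc2cccnc2)c2c[nH]c3ccccc23)cc1` — "not determined" (no result reported)
compound 3 `COc1ccc(Cn2c(CCc3ccccc3)nnc2[C@H](NC(=O)c2cnccn2)c2c[nH]c3ccccc23)c(OC)c1` — 24 nM

Compound 3 holds the higher of the two numbers recorded. Compound 3 gives 24 nM and compound 1 gives 5 nM; the gap between these two values lies beyond the scatter. Compound 2 gives "not determined" (no result reported) and so contributes no number at all. Compounds 1 and 3 differ from each other in more than one place, so the gap between them cannot be assigned to any single change and says nothing on its own about the benzyl substitution.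

Compound 4 `COc1ccc(Cn2c(CCc3ccccc3)nnc2[C@H](NC(=O)c2cnccn2)c2c[nH]c3ccccc23)cc1` has not yet been measured. It differs from compound 3 by hydrogen in place of methoxy on an aromatic carbon — hydrogen in place of methoxy on an aromatic carbon; read one bond further out, 2,4-dimethoxybenzyl becomes 4-methoxybenzyl, the benzyl group that compound 1 and compound 2 carry. Among the measured compounds shown here, no measured pair shows this change alone, so its size is not anchored by a recorded step. Taking the methoxy away at this place is expected to move the number only a little, in no firm direction, with no step beyond the scatter in this assay. The expected step is a 1.2-fold lower number from compound 3 to compound 4 (0.08 log units; within the scatter). Compound 4 is therefore estimated at 20 nM, with a range from 7 nM to 60 nM.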

Compound 4, antagonist equilibrium constant: 530 nM
Estimate against measurement, compound 4: 27-fold (1.42 log units) below; measured number above the stated range.
By their numbers in this assay, from the lowest: compound 1; then compound 3; then compound 4.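

In this assay, the methoxy on the aromatic carbon ortho to a large group now has its first single-place reading: with the pyrazin-2-yl amide held fixed, going from 2,4-dimethoxybenzyl to 4-methoxybenzyl gives a 22-fold higher number from compound 3 to compound 4 (1.34 log units; beyond the scatter) and so this position is far from neutral in this pair. The same new compound also opens a single-place reading at the other end of the molecule, where pyrazin-2-yl in place of 1-amino-1-methylethyl on the carbonyl carbon, with 4-methoxybenzyl held fixed, gives a 110-fold higher number from compound 1 to compound 4 (2.03 log units; beyond the scatter) and so shows that the group on the carbonyl carries a large share of the range seen so far. No measurement at hand accounts for either step.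

The compounds shown leave open whether the methoxy step carries over to the 1-amino-1-methylethyl amide, since the only reading there is with 4-methoxybenzyl, and a single pair cannot show how far it generalises. Also open, as far as these compounds go, is whether another group on that aromatic carbon, such as a hydroxy, an ethoxy or a chlorine, would behave like methoxy or like hydrogen.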